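From 2-aminoethyl to benzyl on a shared core

This account rests on a few compounds, and the source may have more. Where it says the series, first, only, none or still open, it means among the compounds named here.

Measured in a functional assay on HCT-116 cells (Homo sapiens) for cytotoxicity, read by MTT assay, with a stated time of 72 h; a higher number here means a weaker inhibitor, a lower number a stronger inhibitor:
- compound 1 `NCCCNc1c(C(=O)NCc2ccc(F)cc2)nc(Br)c2cccnc12`: 18000 nM
- compound 2 `NCCNc1c(C(=O)NCc2ccc(F)cc2)nc(Br)c2cccnc12`: > 20000 nM (a limit of the assay, not a number)

Compound 2 stands at the limit of > 20000 nM in this assay, at which 1 of the 2 values shown sits, so its true value is not known. Compound 3 `O=C(NCc1ccc(F)cc1)c1nc(Br)c2cccnc2c1NCc1ccccc1` has not yet been measured. It differs from compound 2 by phenyl in place of aminomethyl on a saturated chain carbon bound to a nitrogen on an aromatic ring.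

For the measured compounds named here, the only measured step that bears on this is an at least 1.1-fold higher number from compound 1 to compound 2 (0.04 log units; that floor lies within the scatter), where aminomethyl also leaves. Going by the values given here, no measured step brings in a phenyl. With so little to go on, no change beyond the scatter is expected in this assay. The expected step is an at least 1.3-fold lower number from compound 2 to compound 3 (0.12 log units; that floor lies within the scatter). For compound 3 the estimated value is 15000 nM, with an expected range of 6000 nM to 30000 nM.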

Compound 3, half-maximal inhibitory concentration: > 20000 nM
Compound 3 was reported as a limit; the forecaster's own chance of this, stated with the estimate: 50%; middle value at least 1.3-fold (0.12 log units) from the limit.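

Putting phenyl in place of aminomethyl on this saturated chain carbon brings an aromatic ring into the group and removes its amine, yet compound 3 also ends at a limit of the assay rather than at a number, and it now shares that limit with compound 2: the limit of > 20000 nM in this assay, at which 2 of the 3 values shown sit. Since both are limits, the step between compound 2 and compound 3 cannot be read. For the compounds shown here, the one readable step is an at least 1.1-fold higher number from compound 1 to compound 3 (0.04 log units; that floor lies within the scatter), so benzyl at this place gives no change beyond the scatter in this assay.

As far as these compounds go, how far compound 2 and compound 3 truly lie past the limit stays open. Also open, from the compounds shown here alone, is whether a longer chain ending in an amine, or a carboxylic acid on the chain, would give a value that can be read in this assay.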